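Swapping hydroxy for hydrogen on compound 2

A few compounds are considered here, and "the series" means these few. Any claim that something is new, unique, unknown or untested is made for them only; others in the source may bear on it.

Compound 1 `COc1cc2c(c(OC)c1OC)C/C(=C\c1cc(OC)c(OC)c(OC)c1OC)C2=O`: > 10000 nM
Compound 2 `COc1ccc(/C=C2\Cc3cc(OC)c(OC)c(OC)c3C2=O)cc1O`: > 10000 nM

In a functional assay on MDA-MB-231 cells (Homo sapiens) for antiproliferative activity, read by MTT assay, with a stated time of 48 h (a lower number here means a stronger inhibitor of growth, a higher number a weaker inhibitor of growth), compound 2 gives > 10000 nM, a limit of the assay and not a number. Compound 1 gives > 10000 nM, also a limit. Compound 2 therefore stands at the limit of > 10000 nM in this assay, at which 2 of the 2 values shown sit.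

Compound 3 `COc1ccc(/C=C2\Cc3cc(OC)c(OC)c(OC)c3C2=O)cc1` differs from compound 2 in one place: hydrogen in place of hydroxy on an aromatic carbon. Among the measured compounds shown here, no measured step shows what this change does. For the measured compounds named here, the only guide is compound 2 at > 10000 nM, again a limit. The estimated step is a step that the limit leaves unreadable from compound 2 to compound 3, with no change expected beyond the scatter. For compound 3 the expected value is 12000 nM, with an estimated range from 4000 nM to 40000 nM.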

Compound 3, concentration for 50% growth inhibition: > 10000 nM
Compound 3: only a limit was reported; the forecaster's own chance of this, stated with the estimate: 75%; the middle value does not contradict the limit.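

Among the compounds shown here, compound 2 and compound 3 both sit at a limit in this assay and no step between them can be read: the limit of > 10000 nM in this assay, at which 3 of the 3 values shown sit. From the compounds shown here alone, what swapping hydroxy for hydrogen does to growth inhibition stays open, since neither compound gives an actual number.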